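Swapping an Aminomethyl Chain for a Methoxy Group

The source may report more compounds than this note shows. Statements on the series, on what has been measured and on what is new or still open speak of the compounds shown alone.

In an assay on HEK293 cells for displacement of a labelled ligand from prostaglandin D2 receptor 2 (Homo sapiens), read by scintillation counting, in the presence of a further agent that is not named here (a lower number here means a stronger inhibitor, a higher number a weaker inhibitor), compound 1, with structure `CCNC(=O)c1ccc(Oc2cc(Cl)cc(CC(=O)O)c2)c(NS(=O)(=O)c2ccc(C(F)(F)F)cc2Cl)c1`, gives 28 nM. Compound 2, with structure `CCNCc1ccc(Oc2cccc(CC(=O)O)c2)c(NS(=O)(=O)c2ccccc2)c1`, differs from compound 1 in several places at once, so the two values can be set side by side but no single change accounts for the gap. For compound 2 the this assay reports only a limit, > 10000 nM, which is an edge of the assay rather than a number. That edge appears as the limit of > 10000 nM in this assay, at which 1 of the 2 values shown sits. Compound 2 thus stands at the weak end of the two results shown.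

Compound 3, with structure `COc1ccc(Oc2cccc(CC(=O)O)c2)c(NS(=O)(=O)c2ccccc2)c1`, is not yet measured. It differs from compound 2 by one change: methoxy in place of (ethylamino)methyl on an aromatic carbon. Going by the values given here, no measured pair shows this change on its own, so its effect can only be anticipated. The step expected here, an at least 1.2-fold lower number from compound 2 to compound 3 (0.09 log units; that floor lies within the scatter), is small and not clearly beyond the usual scatter, given that the starting point is itself only a limit. Compound 3 is estimated at 8000 nM, within a range from 2000 nM to 30000 nM, with a fair chance that the assay again reports only a limit.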

Compound 3, half-maximal inhibitory concentration: 1400 nM
The estimate for compound 3 lay 5.7-fold (0.76 log units) above the measured number; measured number outside the range, below it.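

In this assay, replacing (ethylamino)methyl with methoxy at this position, para to a large group and meta to a (phenylsulfonyl)amino group, gives an at least 7.1-fold lower number from compound 2 to compound 3 (0.85 log units; beyond the scatter). That step is only a floor, because compound 2 carries a limit of the assay and not a number: the limit of > 10000 nM in this assay, at which 1 of the 3 values shown sits. The position therefore does not need the (ethylamino)methyl chain, with its nitrogen and its hydrogen-bond donor, for binding to register: with methoxy in that place, compound 3 gives 1400 nM, a real number where the earlier pair offered no single change to read.

The compounds shown do not tell whether the gain comes from methoxy itself or simply from the loss of the amine chain, and a hydroxy group, a plain ethyl chain or a longer ether chain at this position would help separate the two. As far as these compounds go, it also remains open how far the same swap carries over to the core of compound 1, with its chlorine and trifluoromethyl groups, where the position holds an ethyl amide instead.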